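Tetrazole nitrogen substituent: compound 4 against compound 1

This account rests on a few compounds, and the source may have more. Where it says the series, first, only, none or still open, it means among the compounds named here.

Measured compounds in a functional assay on H4 cells for agonist activity at growth hormone secretagogue receptor type 1 (Homo sapiens), read by FLIPR; on this read-out lower numbers stand for an effect already at smaller amounts and higher numbers for an effect only at larger amounts of compound:
compound 1 `CC(C)(N)C(=O)N[C@H](COCc1ccccc1)c1nnnn1CCCc1ccccc1` gives 17 nM
compound 2 `CC(C)(N)C(=O)N[C@H](COCc1ccccc1)c1nnn(Cc2ccccc2NS(C)(=O)=O)n1` gives 426 nM
compound 3 `CC(C)(N)C(=O)N[C@H](COCc1ccccc1)c1nnn(CC#N)n1` gives 1520 nM

Compound 1 stands lowest of the three numbers; compound 2 is nearest and compound 3 furthest, both beyond the scatter. The three differ only in the group carried on the aromatic nitrogen of the shared core. Compound 4 `CC(C)(N)C(=O)N[C@H](COCc1ccccc1)c1nnnn1CCC(=O)NCCCc1ccccc1` is not yet measured in this assay; it differs from compound 1 by (3-phenylpropyl)carbamoyl in place of benzyl on a saturated chain carbon, two bonds along the chain from an aromatic nitrogen. Within the data shown here, the only step measured in one place is a 3.6-fold higher number from compound 2 to compound 3 (0.55 log units; beyond the scatter), which exchanges groups on the chain bound to the same aromatic nitrogen and shows that this position moves the number, though neither compound 2 nor compound 3 carries the chain of compound 1, and no measured step exchanges a benzyl for a carbamoyl group. Compound 4 keeps a phenyl ring, now on an amide-bearing chain. In this assay a modest rise is expected for compound 4, a 3.5-fold higher number from compound 1 to compound 4 (0.55 log units; beyond the scatter), with wide uncertainty. Compound 4 is estimated at 60 nM, range 15 nM to 300 nM.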

Compound 4, half-maximal effective concentration: 59 nM
Compound 4: middle estimate off by 1.0-fold (0.01 log units), on the high side; low and high end bracket the measured number.
By their numbers in this assay, from the lowest: compound 1; then compound 4; then compound 2; then compound 3.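

In this assay, (3-phenylpropyl)carbamoyl in place of benzyl on a saturated chain carbon, two bonds along the chain from an aromatic nitrogen, gives a 3.5-fold higher number from compound 1 to compound 4 (0.54 log units; beyond the scatter). Unlike the earlier step between compounds that lack the chain of compound 1, this one starts from that chain and keeps a phenyl ring, and it shows that a carbamoyl group and a larger substituent at this place cost only a modest step, with compound 4 at 59 nM. No measurement shown explains the size of this step.

From the compounds shown here alone, this single step changes the carbamoyl group and the distance to the phenyl ring together, and their separate shares remain open. Going by these compounds, how a carboxylic acid, an amine or a simple alkyl chain would read at this place also remains open.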